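The source may hold more compounds than are shown below. What is called first, only, known or untested is meant among the compounds shown, and "the series" means these compounds.

Measured so far:
- compound 1 `C=C1C(=O)ON(C)C1c1ccc(OC)cc1`: 5400 nM in a functional assay on HL-60 cells (Homo sapiens) for antiproliferative activity; on this read-out lower numbers stand for stronger inhibition and higher numbers for weaker inhibition
- compound 2 `C=C1C(=O)ON(C)C1c1ccc(Br)cc1`: 5100 nM in this assay

Compound 2 stands level with compound 1: the step of a 1.1-fold lower number from compound 1 to compound 2 (0.02 log units; within the scatter) is within the scatter, so the two numbers cannot be told apart. Compound 3 `C=C1C(=O)ON(C)C1c1ccc([N+](=O)[O-])cc1` has not yet been measured in this assay. It differs from compound 2 by nitro in place of bromo on an aromatic carbon, that is, a nitro group now sits on the aromatic carbon where the bromo stood, para to the group of 8 heavy atoms that forms the rest of the molecule.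

Among the compounds with values here, only one measured step bears on this change, and only loosely: a 1.1-fold lower number from compound 1 to compound 2 (0.02 log units; within the scatter) exchanged one group for another at the same place on the ring and produced no change beyond the scatter. Nothing is known about a nitro group at that place. The expectation therefore rests on that single step, and the step of a 1.0-fold lower number from compound 2 to compound 3 (0.01 log units; within the scatter) is estimated to be none beyond the scatter. Compound 3 is expected to give about 5000 nM, with a range from 2000 nM to 15000 nM.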

Compound 3, half-maximal inhibitory concentration: 7400 nM
The estimate for compound 3 lay 1.5-fold (0.17 log units) below the measured number, within the range that was stated.
By their numbers in this assay, from the lowest: compounds 2, 1 and 3 (each within the scatter of the next).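

In this assay a third group now sits on the same aromatic carbon, and the number still shows no readable change, with a 1.5-fold higher number from compound 2 to compound 3 (0.16 log units; within the scatter) and a 1.4-fold higher number from compound 1 to compound 3 (0.14 log units; within the scatter) both lying within the scatter. This is a stricter test than the earlier swap, since nitro brings more heavy atoms than bromo and two hydrogen-bond acceptors where bromo has none, yet bromo, methoxy and nitro cannot be told apart at this position in these three compounds. Nothing measured here explains why these groups give such similar numbers.

The compounds shown leave open whether this insensitivity extends to quite different groups at this place, such as an amine, a carboxylic acid or a longer alkyl chain, any of which could either match these numbers or move them beyond the scatter. All three compounds also share the rest of the core, so they cannot tell whether the same swaps would stay just as silent if another part of the molecule were changed.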